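The source may report more compounds than this note shows. Statements on the series, on what has been measured and on what is new or still open speak of the compounds shown alone.

Going by the values given here, compound 1, with the structure `CCc1cc(C(C)=O)c(O)cc1OCCCCC(C)(C)C#N`, stands at the top of the three numbers measured so far: in an assay on isolated protein for inhibition of leukotriene B4 receptor 1 (Homo sapiens), tested at 10 uM (a lower number here means less inhibition, a higher number more inhibition at the concentration tested (going by the name of the read-out)), compound 1 gives 79%. Compound 2, with the structure `C=CCCCCOc1cc(O)c(C(C)=O)cc1CC=C`, comes nearest; in this assay compound 2 gives 73%, a gap within the usual scatter, so the two cannot be told apart. Compound 3, with the structure `CCCc1cc(C(C)=O)c(O)cc1OCCCCC(=O)O`, lies furthest away; in this assay compound 3 gives 11%, a gap well beyond the scatter. No two of these three compounds differ in only one place, so no single step can be read from them.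

Compound 4, not yet measured, has the structure `CCc1cc(C(C)=O)c(O)cc1OCCCCCCc1nnn[nH]1`. It differs from compound 1 in one place: 2-(1H-tetrazol-5-yl)ethyl in place of 1-cyano-1-methylethyl on a saturated chain carbon, four bonds along the chain from an oxygen on an aromatic ring. The incoming tetrazole ring carries a hydrogen-bond donor and three acceptors where the leaving nitrile group carried one acceptor and no donor. Among the compounds with values here, no measured pair shows what such a swap does here, so the expectation rests on the wide spread of the three measured values. The step from compound 1 to compound 4 is expected to go downward by a moderate amount, a number 34 percentage points lower from compound 1 to compound 4 (beyond the scatter), with wide uncertainty. Compound 4 is therefore estimated to give about 45% in this assay, somewhere between 15% and 75%.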

Compound 4, a percentage reported as inhibition, at one concentration (the size of the read-out at that concentration, not a potency): 91%
Compound 4: middle estimate off by 46 percentage points, on the low side; the measured number lies above the stated range.
By their numbers in this assay, from the lowest: compound 3; then compounds 2 and 1 (each within the scatter of the next); then compound 4.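

In this assay, going by these compounds alone, putting 2-(1H-tetrazol-5-yl)ethyl in place of 1-cyano-1-methylethyl gives a number 12 percentage points higher from compound 1 to compound 4 (beyond the scatter), the first step in this set that can be read at a single place. It shows that this saturated chain carbon, four bonds along the chain from an oxygen on an aromatic ring, accepts a very different end group without any loss of inhibition at the concentration tested: a five-membered aromatic ring with 4 hetero atoms and a hydrogen-bond donor replaces a nitrile with no donor, and the number still rises. Nothing available here explains that rise.

The compounds shown leave open whether the tetrazole ring or the ethyl link counts for more, as this one step changes both the end group and the way it is attached to the chain. Also open, going by these compounds, is how an amide or a primary amine would behave at the same place on the core of compound 1, and whether a tetrazole on a shorter chain would hold the same level of inhibition.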